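Replacing Nitro by Amino: Two Measured Pairs

This account rests on a few compounds, and the source may have more. Where it says the series, first, only, none or still open, it means among the compounds named here.

Compound 1 `COc1ccc(/C=C\c2ccc3ccccc3c2)cc1[N+](=O)[O-]` gives > 20000 nM in a functional assay on A549 cells (Homo sapiens) for inhibition (on this read-out lower numbers stand for stronger inhibition and higher numbers for weaker inhibition), which is a limit of the assay and not a number.
Compound 2 `COc1ccc(/C=C\c2ccc3ccccc3c2)cc1N` gives > 20000 nM in this assay, also a limit.
Compound 3 `COc1cc(/C=C/c2ccc3ccccc3c2)cc([N+](=O)[O-])c1OC` gives > 10000 nM in this assay, again a limit.

The change from compound 1 to compound 2 is amino in place of nitro on an aromatic carbon. Its size is a step that the two limits leave unreadable from compound 1 to compound 2: both values are limits. Compound 4 `COc1cc(/C=C/c2ccc3ccccc3c2)cc(N)c1OC` has not been measured; it differs from compound 3 by amino in place of nitro on an aromatic carbon, the same kind of change, though here the place is also meta to a methoxy group. The difference between the two cores is not broken down here. Two values sit at the limit of > 20000 nM in this assay, at which 2 of the 3 values shown sit, and one at the limit of > 10000 nM in this assay, at which 1 of the 3 values shown sits. The step from compound 3 to compound 4 is expected to be a step that the limit leaves unreadable from compound 3 to compound 4, resting on a step that the two limits leave unreadable from compound 1 to compound 2 and on compound 3 sitting at the limit of > 10000 nM in this assay, at which 1 of the 3 values shown sits. Compound 4 is estimated at 30000 nM.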

Compound 4, half-maximal inhibitory concentration: 2150 nM
The estimate for compound 4 lay 14-fold (1.14 log units) above the measured number; the measured number lies below the stated range.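

In this assay, amino in place of nitro on an aromatic carbon gives an at least 4.6-fold lower number from compound 3 to compound 4 (0.66 log units; beyond the scatter), a clear gain in inhibition on that core. The same change on the core of compound 1 cannot be read, both values there being limits, and a single readable step on one core does not show that the gain carries over to another. Compound 2 gives > 20000 nM, which is a limit.

The compounds shown leave open whether another group on the same carbon, such as a hydroxyl or an acetamide, would match amino. They also leave open how much of the number for compound 4 depends on its two methoxy groups.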